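From Fluoro to Methoxy: A Small Step Expected

The source may report more compounds than this note shows. Statements on the series, on what has been measured and on what is new or still open speak of the compounds shown alone.

Measured in a functional assay on HT-29 cells (Homo sapiens) for antiproliferative activity, read by sulforhodamine B assay, with a stated time of 72 h; a higher number here means a weaker inhibitor, a lower number a stronger inhibitor:
- compound 1 `S=C(NCc1ccccc1)N/N=C/c1ccc2ccccc2n1`: 75700 nM
- compound 2 `S=C(N/N=C/c1ccc2ccccc2n1)Nc1ccc(Br)cc1`: 54400 nM
- compound 3 `Fc1ccc(NC(=S)N/N=C/c2ccc3ccccc3n2)cc1`: 28500 nM

Compound 3 stands clear of compound 1 only, with a 2.7-fold lower number from compound 1 to compound 3 (0.42 log units; beyond the scatter). Its gap to compound 2 is small: a 1.9-fold lower number from compound 2 to compound 3 (0.28 log units; within the scatter). Compound 4 `COc1ccc(NC(=S)N/N=C/c2ccc3ccccc3n2)cc1` carries methoxy in place of fluoro on an aromatic carbon, para to a large group (methoxy in place of fluoro on an aromatic carbon). For the measured compounds named here, the only measured swap at this place is that same bromo-to-fluoro step, and it stayed within the scatter. Going by the values given here, no methoxy compound has a measured value yet, so no step beyond the scatter is expected, and neither direction is favoured. The expected step is a 1.1-fold higher number from compound 3 to compound 4 (0.05 log units; within the scatter) in this assay. Compound 4 is estimated at 32000 nM, with an expected range of 12000 nM to 85000 nM.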

Compound 4, half-maximal inhibitory concentration: 82300 nM
For compound 4 the middle estimate is 2.6-fold (0.41 log units) below the measured one; the range from low to high includes it.
By their numbers in this assay, from the lowest: compounds 3, 2, 1 and 4 (each within the scatter of the next, the first and the last beyond it).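

In this assay the group on this ring does matter: methoxy in place of fluoro gives a 2.9-fold higher number from compound 3 to compound 4 (0.46 log units; beyond the scatter) and so lies beyond the scatter, which the bromo-to-fluoro swap did not. The other two steps, a 1.5-fold higher number from compound 2 to compound 4 (0.18 log units; within the scatter) and a 1.1-fold higher number from compound 1 to compound 4 (0.04 log units; within the scatter), both stay within the scatter, so methoxy cannot be told from bromo here, nor the 4-methoxyphenyl group from benzyl. Nothing available explains the step from fluoro to methoxy. From the compounds shown here alone, whether an amine or a hydroxyl at this place would fall nearer fluoro or methoxy stays open.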